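This account rests on a few compounds, and the source may have more. Where it says the series, first, only, none or still open, it means among the compounds named here.

Measured so far:
- compound 1, `O=C(N[C@@H](CO)C(=O)NO)c1ccc(C#Cc2ccccc2)cc1`: 28000 nM
- compound 2, `O=C(NC1(C(=O)NO)CCN(Cc2ccccc2)CC1)c1ccc(C#Cc2ccccc2)cc1`: < 1000 nM

For the measured compounds named here, compound 1 is the only compound of the pair with a measured number in a physicochemical assay for solubility; a higher number here means a more soluble compound, a lower number a less soluble compound; in this assay compound 1 gives 28000 nM. For compound 2 this assay reports < 1000 nM, which is a limit of the assay and not a number, (the limit of < 1000 nM in this assay, at which 1 of the 2 values shown sits). Going by the values given here, no step between compound 1 and compound 2 is counted, as they differ in more than one place; the two values show only that compound 1 gives a number and compound 2 a limit.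

The next compound is compound 3, `NC[C@H](NC(=O)c1ccc(C#Cc2ccccc2)cc1)C(=O)NO`. Against compound 1 the change is amino in place of hydroxy on a saturated chain carbon, two bonds along the chain from an amide-type nitrogen and a carbonyl carbon. Among the compounds with values here, no measured step of this kind is available, so the expectation rests on compound 1 alone. The change is expected to move this assay only modestly and, if at all, upwards; the step from compound 1 to compound 3 is estimated at a 1.8-fold higher number from compound 1 to compound 3 (0.25 log units; within the scatter). Compound 3 is expected to give 50000 nM in this assay, with a range from 15000 nM to 200000 nM.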

Compound 3, solubility: 13000 nM
For compound 3 the middle estimate is 3.8-fold (0.59 log units) above the measured one; the whole stated range lies above it.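

For the compounds shown here, the first one-place comparison falls on the saturated chain carbon, two bonds along the chain from an amide-type nitrogen and a carbonyl carbon: in this assay, amino in place of hydroxy gives a 2.2-fold lower number from compound 1 to compound 3 (0.33 log units; beyond the scatter). This position is therefore not silent to the exchange of hydroxymethyl for aminomethyl, although the size of the step is modest, and compound 3 gives 13000 nM, a measured number in this assay and not a limit. Nothing measured in the series gives a cause for this step.

As far as these compounds go, whether the same direction holds for other groups on this carbon, such as a carboxylic acid, a methoxy group or a longer chain ending in an amine, stays open, since a single step at one position makes no trend. Compound 2 carries a limit of the assay and not a number, and it differs from compound 1 in more than one place, which leaves the effect of its changes on the series unresolved: the limit of < 1000 nM in this assay, at which 1 of the 3 values shown sits.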